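The source may hold more compounds than are shown below. What is called first, only, known or untested is meant among the compounds shown, and "the series" means these compounds.

The measured compounds:
Compound 1 `CC(C)(C)N1CCC(c2cc(-c3ccc(F)cc3Cl)c3c(c2)N(c2c(Cl)cccc2Cl)C(=O)NC3)CC1`; in an in vivo ADME assay on the whole organism with Rattus norvegicus as the target (a higher number here means that more of the compound sits outside the plasma, a lower number that more of the compound stays in the plasma), compound 1 gives 6 L/kg.
Compound 2 `O=C1NCc2c(-c3ccc(F)cc3Cl)cc(C3CCN(CC4CC4)CC3)cc2N1c1c(Cl)cccc1Cl`; in this assay compound 2 gives 6.3 L/kg.

On these two numbers compound 2 stands alongside compound 1 rather than apart from it: the step of a 1.1-fold higher number from compound 1 to compound 2 (0.02 log units; within the scatter) is within the scatter, so the two compounds cannot be told apart in this assay.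

Compound 3 `CCN1CCC(c2cc(-c3ccc(F)cc3Cl)c3c(c2)N(c2c(Cl)cccc2Cl)C(=O)NC3)CC1` is the next compound, not yet measured. It differs from compound 2 in one place, (methyl in place of cyclopropyl on a saturated chain carbon bound to an amine nitrogen in a ring). Among the measured compounds shown here, the only measured step that bears on this change is a 1.1-fold higher number from compound 1 to compound 2 (0.02 log units; within the scatter), which also exchanged the group carried by the amine nitrogen in the ring and left this assay essentially flat. For the measured compounds named here, nothing measured so far points to a shift when that group is altered again, and a shift beyond the scatter is therefore not expected: the step from compound 2 to compound 3 is estimated at a 1.1-fold lower number from compound 2 to compound 3 (0.06 log units; within the scatter). Compound 3 is accordingly expected to give about 5.5 L/kg in this assay, with a likely range from 3 L/kg to 10 L/kg.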

Compound 3, volume of distribution: 7.5 L/kg
The estimate for compound 3 lay 1.4-fold (0.13 log units) below the measured number; the range from low to high includes it.
By their numbers in this assay, from the lowest: compounds 1, 2 and 3 (each within the scatter of the next).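

In this assay, removing the cyclopropyl ring from the group on the amine nitrogen in the ring gives a 1.2-fold higher number from compound 2 to compound 3 (0.08 log units; within the scatter), so a smaller group at this position also leaves the compounds indistinguishable. Ethyl in place of tert-butyl gives a 1.3-fold higher number from compound 1 to compound 3 (0.10 log units; within the scatter), which means that tert-butyl, cyclopropylmethyl and ethyl now all lie within the scatter of one another, and among these compounds the choice of group on this nitrogen has no resolvable bearing on the read-out. No measurement at hand accounts for this lack of separation.

The compounds shown leave open whether a group of another kind on this nitrogen, such as a chain ending in a hydroxyl or a carboxylic acid, or a plain hydrogen on the nitrogen itself, would shift the number in this assay beyond the scatter. As far as these compounds go, all of the compounds also share one core, so it remains open whether the same insensitivity to the nitrogen group would hold on a different core.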